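This account rests on a few compounds, and the source may have more. Where it says the series, first, only, none or still open, it means among the compounds named here.

Measured so far in an assay for inhibition of RAC-alpha serine/threonine-protein kinase (Homo sapiens), read by HTRF, with a stated time of 1 h; a higher number here means a weaker inhibitor, a lower number a stronger inhibitor:
- compound 1 `Cn1ncc(Cl)c1-c1cc(C(=O)NC2CNCCC2c2ccc(C(F)(F)F)cc2)oc1Cl`: 7.2 nM
- compound 2 `Cn1ncc(Cl)c1-c1cc(C(=O)N[C@@H]2CN[C@H](CC(O)CO)C[C@H]2c2ccc(F)c(F)c2)oc1Cl`: 3.31 nM
- compound 3 `Cn1ncc(Cl)c1-c1cc(C(=O)N[C@@H]2CN[C@H](CC(O)CO)C[C@H]2c2ccc(Cl)c(Cl)c2)oc1Cl`: 3.79 nM

Compound 1 gives the highest of the three numbers; its gap to compound 3 lies within the scatter, its gap to compound 2 beyond it. Going by the values given here, the single step in hand, a 1.1-fold higher number from compound 2 to compound 3 (0.06 log units; within the scatter), concerns the aryl group, not the stereochemistry.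

Compound 4 `Cn1ncc(Cl)c1-c1cc(C(=O)N[C@H]2CNCC[C@@H]2c2ccc(C(F)(F)F)cc2)oc1Cl` differs from compound 1 as follows: the two compounds have the same atoms and bonds; at least one stereo element is drawn with a configuration in one of them and without one in the other: 2 of 2 stereo elements differ; a stereocentre at a saturated ring carbon is drawn without a configuration in compound 1 and R in compound 4; a stereocentre at a saturated ring carbon is drawn without a configuration in compound 1 and R in compound 4. Among the compounds with values here, no measured step addresses drawing a configuration where none was drawn, so the change is unsupported by this series. A single defined isomer may, if the undefined material is a mixture, give a somewhat lower number than compound 1; the expected step of a 1.8-fold lower number from compound 1 to compound 4 (0.26 log units; within the scatter) is therefore small and uncertain. The estimate for compound 4 is 4 nM, expected within 1.5 nM to 15 nM.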

Compound 4, half-maximal inhibitory concentration: 127 nM
Compound 4: middle estimate off by 32-fold (1.50 log units), on the low side; the measured number lies above the stated range.
By their numbers in this assay, from the lowest: compounds 2, 3 and 1 (each within the scatter of the next, the first and the last beyond it); then compound 4.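

In this assay, going by these compounds alone, the change gives an 18-fold higher number from compound 1 to compound 4 (1.25 log units; beyond the scatter) with no atom or bond altered, so this position responds strongly to configuration, which the aryl step among the earlier compounds could not show. Compound 4 is therefore not the form that accounts for the number of compound 1, if that material is a mixture. The only structural difference available to explain the gap is a stereochemical one: the fact that one of compounds 1 and 4 is drawn with a defined configuration and the other without, at the place where they differ.

Open, going by these compounds, is which other configuration at these two ring carbons gives the lower number. Also open, on these data alone, is how a nitrile in place of trifluoromethyl would behave in each configuration.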